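The source may report more compounds than this note shows. Statements on the series, on what has been measured and on what is new or still open speak of the compounds shown alone.

Measured so far:
compound 1 `O=C(/C=C/c1ccc2c(c1)B(O)OC2)c1cccs1` — 4600 nM
compound 2 `Cn1cccc1C(=O)/C=C/c1ccc2c(c1)B(O)OC2` — > 100000 nM
compound 3 `O=C(/C=C/c1ccc2c(c1)B(O)OC2)c1ccc(Cl)cc1` — 7900 nM

All three share one core and differ only in the group on the carbonyl carbon. In a functional assay on MDA-MB-231 cells (Homo sapiens) for cytotoxicity, read by MTT assay, with a stated time of 48 h (a higher number here means a weaker inhibitor, a lower number a stronger inhibitor), compound 1 gives 4600 nM, the lowest of the two numbers shown. Compound 3 gives 7900 nM, and the step of a 1.7-fold higher number from compound 1 to compound 3 (0.23 log units; within the scatter) stays within the scatter, so these two cannot be set in order. For compound 2 the assay reports only a limit, > 100000 nM. The step of an at least 21-fold higher number from compound 1 to compound 2 (1.33 log units; beyond the scatter) is large, as is an at least 12-fold lower number from compound 2 to compound 3 (1.10 log units; beyond the scatter).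

Compound 4 `O=C(/C=C/c1ccc2c(c1)B(O)OC2)c1ccccc1F` differs from compound 1 by 2-fluorophenyl in place of thiophen-2-yl on a carbonyl carbon. The measured step that bears on this is a 1.7-fold higher number from compound 1 to compound 3 (0.23 log units; within the scatter), where 4-chlorophenyl in place of thiophen-2-yl left the number within the scatter. The large step to 1-methyl-1H-pyrrol-2-yl does not bear here, since compound 4 carries a six-membered aromatic ring of carbon only, as compound 3 does. A step of a 1.3-fold higher number from compound 1 to compound 4 (0.12 log units; within the scatter) is therefore expected, not beyond the scatter. Compound 4 is estimated at 6000 nM, with a range from 2500 nM to 15000 nM.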

Compound 4, half-maximal inhibitory concentration: 2200 nM
Compound 4: the middle estimate sits 2.7-fold (0.44 log units) above what was measured; measured number outside the range, below it.
By their numbers in this assay, from the lowest: compound 4; then compounds 1 and 3 (each within the scatter of the next). At a limit, above all of these: compound 2.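

In this assay, the group on the carbonyl carbon can move the number downward from thiophen-2-yl as well as upward: a 2.1-fold lower number from compound 1 to compound 4 (0.32 log units; beyond the scatter), whereas the change to 4-chlorophenyl in compound 3 stayed within the scatter. Two groups with the same six-membered aromatic ring of carbon only are also separated here, with a 3.6-fold lower number from compound 3 to compound 4 (0.56 log units; beyond the scatter), so the ring type alone does not set the number, and compound 4 now has the lowest number of the series, its steps to all three others being printed as beyond the scatter. The comparison an at least 45-fold lower number from compound 2 to compound 4 (1.65 log units; beyond the scatter) widens the gap to the 1-methyl-1H-pyrrol-2-yl compound, but compound 2 carries a limit and not a number, so this step has no exact size: the limit of > 100000 nM in this assay, at which 1 of the 4 values shown sits.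

Compounds 3 and 4 differ in both the halogen and its place on the ring, so the two contributions cannot be separated from these values, and the series offers no measured reason for the difference. An unsubstituted phenyl would give the reference for both, and a ring carrying a methoxy group or an amine would test whether anything other than a halogen is tolerated on this ring.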